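Working notes on compound 4 ahead of its measurement

The source may hold more compounds than are shown below. What is called first, only, known or untested is meant among the compounds shown, and "the series" means these compounds.

Measured so far, in an ADME assay on the whole organism for cytotoxicity, with Artemia salina as the target, with a stated time of 24 h; a higher number here means that more compound is needed for the effect, a lower number that less compound is needed:
- compound 1 `Cc1ccc(S(=O)(=O)NC(=O)Nc2ccccc2C(=O)/C=C/c2ccccc2O)cc1` gives 32.3 ug/mL
- compound 2 `Cc1ccc(S(=O)(=O)NC(=O)Nc2ccccc2C(=O)/C=C/c2ccccc2[N+](=O)[O-])cc1` gives 40.1 ug/mL
- compound 3 `Cc1ccc(S(=O)(=O)NC(=O)Nc2ccccc2C(=O)/C=C/c2ccccc2Cl)cc1` gives 12.8 ug/mL

Compound 3 stands lowest of the three numbers in this assay. The two steps leading to it are both beyond the scatter but modest: a 2.5-fold lower number from compound 1 to compound 3 (0.40 log units; beyond the scatter) and a 3.1-fold lower number from compound 2 to compound 3 (0.50 log units; beyond the scatter). The step between the other two, a 1.2-fold higher number from compound 1 to compound 2 (0.09 log units; within the scatter), stays within the scatter.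

Compound 4 `Cc1ccc(S(=O)(=O)NC(=O)Nc2ccccc2C(=O)/C=C/C=C/c2ccccc2)cc1` differs from compound 3 in one place: 2-phenylethenyl in place of 2-chlorophenyl on a double-bonded chain carbon bound to a double-bonded chain carbon. Among the compounds with values here, none of the three measured steps touches the chain; each of them exchanges one group on the aromatic ring of the chain terminus, so no measured step bears directly on this change. All that can be taken from them is the range of step sizes seen so far, none larger than modest, and the observation that the two compounds without chloro sit at higher numbers, because compound 1 gives 32.3 ug/mL and compound 2 gives 40.1 ug/mL.

The expected step for compound 4 in this assay is therefore a 2.0-fold higher number from compound 3 to compound 4 (0.29 log units; within the scatter), a modest rise that may fall within the scatter. The estimate for compound 4 is 25 ug/mL, within 10 ug/mL to 60 ug/mL.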

Compound 4, concentration for half-maximal effect: 18.2 ug/mL
For compound 4 the middle estimate is 1.4-fold (0.14 log units) above the measured one; low and high end bracket the measured number.
By their numbers in this assay, from the lowest: compounds 3, 4, 1 and 2 (each within the scatter of the next, the first and the last beyond it).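

In this assay, the exchange at the double-bonded chain carbon bound to a double-bonded chain carbon gives a 1.4-fold higher number from compound 3 to compound 4 (0.15 log units; within the scatter) and so stays within the scatter, which shows that 2-phenylethenyl can take the place of 2-chlorophenyl without a readable change. Compound 4 carries no chlorine, so the earlier picture of the compounds without chloro sitting at higher numbers does not extend to it, although compound 1 and compound 2 still fit that picture. The same group gives a 2.2-fold lower number from compound 2 to compound 4 (0.34 log units; beyond the scatter) when set against 2-nitrophenyl but a 1.8-fold lower number from compound 1 to compound 4 (0.25 log units; within the scatter) when set against 2-hydroxyphenyl, so only the first of these two steps can be read as a real difference, and no measured evidence explains any of the three steps.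

The compounds shown leave open whether a chloro on the phenyl of the 4-phenylbuta-1,3-dien-1-yl chain would move the number beyond the scatter of compound 4, since the longer chain and the loss of chloro arrive together in this step. They also leave open how a saturated chain of the same length, a still longer conjugated chain, or an amine or a carboxylic acid on the terminal phenyl would read in this assay at this place.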